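The compounds below may be only part of what the source reports. "The series", "measured", "known", "first", "only" and "open" are said of these compounds alone.

Measured in a functional assay on HCT-116 cells (Homo sapiens) for cytotoxicity, read by MTT assay, with a stated time of 72 h; a lower number here means a stronger inhibitor, a higher number a weaker inhibitor:
- compound 1 `O=C1C=CCC/C1=C\C=C\c1ccc(Cl)cc1`: 3500 nM
- compound 2 `O=C1C=CCC/C1=C\C=C\c1ccc(Br)cc1`: 5200 nM

Within the data shown here, only these two compounds have numbers so far. Among the measured compounds shown here, compound 2, at 5200 nM, cannot be separated from its sole neighbour: the measured step is a 1.5-fold higher number from compound 1 to compound 2 (0.17 log units; within the scatter). Compound 2 therefore stands level with compound 1 in this assay, and the pair gives no ranking.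

The next compound is compound 3 `O=C1C=CCC/C1=C\C=C\c1ccc([N+](=O)[O-])cc1`, reached from compound 2 by nitro in place of bromo on an aromatic carbon. The nitro sits on the same aromatic carbon, para to a large group, and the rest of the shared core is unchanged.

For the measured compounds named here, one measured step bears on this change, a 1.5-fold higher number from compound 1 to compound 2 (0.17 log units; within the scatter). Going by the values given here, it is a weak guide, as it exchanges chloro for bromo and no nitro compound has yet been measured. With no step beyond the scatter seen so far, none is firmly expected here, and a slightly lower number is only a tentative lean. The expected step is a 1.5-fold lower number from compound 2 to compound 3 (0.17 log units; within the scatter). The range is kept wide, given that a single small step supports it. For compound 3 the estimated value is 3500 nM, with an expected range of 1000 nM to 11000 nM.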

Compound 3, half-maximal inhibitory concentration: 5000 nM
Estimate against measurement, compound 3: 1.4-fold (0.15 log units) below, within the range that was stated.
By their numbers in this assay, from the lowest: compounds 1, 3 and 2 (each within the scatter of the next).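

The nitro group brings 3 heavy atoms and 2 hydrogen-bond acceptors to the aromatic carbon para to a large group, where bromo brought a single bromine and no acceptor, yet in this assay this exchange gives a 1.0-fold lower number from compound 2 to compound 3 (0.02 log units; within the scatter) and leaves the two compounds level. The exchange of chloro for nitro gives a 1.4-fold higher number from compound 1 to compound 3 (0.15 log units; within the scatter) and likewise stays within the scatter, so the level reading now extends beyond the two halogens to a group of a different atom make-up, and chloro, bromo and nitro cannot be ranked at this position. No supporting measurement bears on why these three groups read alike, so the level result stands without an explanation.

On these data alone, whether any group at this aromatic carbon can move the number beyond the scatter remains open, for instance an amine, a carboxylic acid or a methoxy group. Also open, as far as these compounds go, is whether the shared core responds to a change elsewhere, such as a longer chain in place of the present link to the aromatic ring.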